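This account rests on a few compounds, and the source may have more. Where it says the series, first, only, none or still open, it means among the compounds named here.

Measured in a functional assay on DU-145 cells (Homo sapiens) for inhibition, read by trypan blue exclusion, with a stated time of 96 h; a lower number here means a stronger inhibitor of growth, a higher number a weaker inhibitor of growth:
- compound 1 `O=C(/C(=C\c1ccc(Br)cc1)SCc1ccc(Cl)cc1)c1ccc(Br)cc1` gives 1000 nM
- compound 2 `O=C(/C(=C\c1ccc(Br)cc1)SCc1ccc(Cl)cc1)c1ccc(Cl)cc1` gives 1000 nM
- compound 3 `O=C(/C(=C\c1ccc(Br)cc1)Sc1ccc(Br)cc1)c1ccc(Cl)cc1` gives 1000 nM

Compound 2 stands level with compound 1 and compound 3 at the digits shown. The next structure, compound 4 `CN(C)c1ccc(/C=C(/SCc2ccc(Cl)cc2)C(=O)c2ccc(Cl)cc2)cc1`, differs from compound 2 as follows: dimethylamino in place of bromo on an aromatic carbon. This puts dimethylamino in place of bromo on an aromatic carbon, para to a large group.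

Going by the values given here, two measured steps bear on this change. Among the compounds with values here, the first is no change at the digits printed from compound 1 to compound 2 (within the scatter), with chloro in place of bromo on an aromatic carbon. The second is no change at the digits printed from compound 2 to compound 3 (within the scatter), with 4-bromophenyl in place of 4-chlorobenzyl on a sulfur. Both lie within the scatter. Within the data shown here, neither replaces the bromo that leaves here, and no measured compound carries dimethylamino, so the support is only indirect.

No shift beyond the scatter is expected in this assay, in either direction. The expected change is a 1.3-fold lower number from compound 2 to compound 4 (0.10 log units; within the scatter). For compound 4 the estimated value is 800 nM, with an expected range from 200 nM to 3000 nM.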

Compound 4, concentration for 50% growth inhibition: > 100000 nM
Compound 4: only a limit was reported; the forecaster's own chance of this, stated with the estimate: 5%; middle value at least 120-fold (2.09 log units) from the limit.
By their numbers in this assay, from the lowest: compounds 1, 2 and 3 (each within the scatter of the next). At a limit, above all of these: compound 4.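

In this assay, going by these compounds alone, dimethylamino in place of bromo on this aromatic carbon, para to a large group, gives an at least 100-fold higher number from compound 2 to compound 4 (2.00 log units; beyond the scatter), the only step beyond the scatter. The earlier steps, no change at the digits printed from compound 1 to compound 2 (within the scatter) and no change at the digits printed from compound 2 to compound 3 (within the scatter), changed other places and left this bromo in place, so the series had not yet shown that this position responds to substitution. For compound 4, the value > 100000 nM is a limit and not a number.

On these data alone, how other groups fare on this aromatic carbon remains open, for example a methoxy, a primary amine or a carboxylic acid, and so does whether a chloro here would match the bromo. Also open, as far as these compounds go, is whether 4-(dimethylamino)phenyl has the same effect when the sulfur carries the 4-bromophenyl of compound 3.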